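Removing Both Chlorines from the Aryl Piperazine

This account rests on a few compounds, and the source may have more. Where it says the series, first, only, none or still open, it means among the compounds named here.

Three compounds share one core and differ only in the group on an amine nitrogen in a ring. Compound 1 `S=c1oc(-c2ccc3c(c2)OCCO3)nn1CN1CCN(C(c2ccccc2)c2ccccc2)CC1` carries a benzhydryl group there, and in a functional assay on SW 1116 cells (Homo sapiens) for antiproliferative activity, read by MTT assay, with a stated time of 48 h (on this read-out higher numbers stand for weaker inhibition and lower numbers for stronger inhibition), compound 1 gives 21600 nM. Compound 2 `Cc1ccc(N2CCN(Cn3nc(-c4ccc5c(c4)OCCO5)oc3=S)CC2)c(C)c1` carries a 2,4-dimethylphenyl group; in this assay compound 2 reaches only the limit of the assay, > 50000 nM, so no number is known for it. Compound 3 `S=c1oc(-c2ccc3c(c2)OCCO3)nn1CN1CCN(c2cccc(Cl)c2Cl)CC1` carries a 2,3-dichlorophenyl group, and in this assay compound 3 gives 37100 nM, the highest of the two numbers shown; the step from compound 1 lies within the scatter, so the two cannot be ordered.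

Among the measured compounds shown here, the only measured step at this position, an at least 1.3-fold lower number from compound 2 to compound 3 (0.12 log units; that floor lies within the scatter), is a floor that lies within the scatter (the limit of > 50000 nM in this assay, at which 1 of the 3 values shown sits), so it shows no real movement.

Compound 4 `S=c1oc(-c2ccc3c(c2)OCCO3)nn1CN1CCN(c2ccccc2)CC1` is the next step: phenyl in place of 2,3-dichlorophenyl on an amine nitrogen in a ring. Nothing measured here gives a reason to expect a change beyond the scatter, since every aryl group tried on this nitrogen has sat at or near the weak end. Compound 4 is therefore expected to remain weak, with the step from compound 3 estimated as a 1.1-fold lower number from compound 3 to compound 4 (0.03 log units; within the scatter) and a value of about 35000 nM, within 12000 nM to 80000 nM.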

Compound 4, half-maximal inhibitory concentration: > 50000 nM
Compound 4 was reported as a limit; the forecaster's own chance of this, stated with the estimate: 35%; middle value at least 1.4-fold (0.15 log units) away from the limit.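

Compound 4, which has a plain phenyl on the ring nitrogen, is reported in this assay only as a limit, not as a number. The step is an at least 1.3-fold higher number from compound 3 to compound 4 (0.12 log units; that floor lies within the scatter), so removing both chlorines produces no real movement, and these compounds give no sign that the chlorines matter at this position. The step between compound 2 and compound 4 cannot be read, and comparisons among these aryl groups remain blunt because the weak end of the read-out is now crowded: the limit of > 50000 nM in this assay, at which 2 of the 4 values shown sit.

Compound 1, with its benzhydryl group, gives 21600 nM, which is a measured number, but its step to compound 4 is not readable from what is shown. As far as these compounds go, it stays open whether a benzyl group, a pyridine ring, or a phenyl ring carrying a methoxy or hydroxyl group on this nitrogen would give a number clearly away from the limit and so reveal a real trend at this position.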